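Two limits and an untested fluoropyridine isomer

A few compounds are considered here, and "the series" means these few. Any claim that something is new, unique, unknown or untested is made for them only; others in the source may bear on it.

Compound 1 `CC(Oc1ccc(Cl)cc1Cl)C(=O)NCc1ccccc1Cl` gives > 100000 nM in an ADME assay on CHO cells (Cricetulus griseus) for cytotoxicity, read by LDH release (a higher number here means a weaker inhibitor, a lower number a stronger inhibitor), as a limit
Compound 2 `CC(Oc1ccc(Cl)cc1Cl)C(=O)NCc1ccc(F)nc1` gives > 100000 nM in this assay as a limit

Both entries are limits and not numbers. Compound 2 stands on the limit of > 100000 nM in this assay, at which 2 of the 2 values shown sit, and has no number of its own. Compound 3 `CC(Oc1ccc(Cl)cc1Cl)C(=O)NCc1ccc(F)cn1` has the same atoms as compound 2 joined differently, as 5-fluoropyridin-2-yl in place of 6-fluoropyridin-3-yl on a saturated chain carbon bound to an amide-type nitrogen shows, with 5-fluoropyridin-2-yl in place of 6-fluoropyridin-3-yl on a saturated chain carbon bound to an amide-type nitrogen. Going by the values given here, since the only measured step is a step that the two limits leave unreadable from compound 1 to compound 2 with no size to carry forward, no shift beyond the scatter is expected in this assay for compound 3, and another limit is the likeliest report. The expected step is a number no higher from compound 2 to compound 3 (the limit leaves the size open) and no more. Compound 3 is expected near 100000 nM with an estimated range from 50000 nM to 150000 nM in this assay.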

Compound 3, half-maximal inhibitory concentration: > 100000 nM
Compound 3: a limit, no number; the forecaster's own chance of this, stated with the estimate: 85%; the middle value lies on the limit itself.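

In this assay, going by these compounds alone, compound 3 gives > 100000 nM as a limit and not a number, so no step among compound 1, compound 2 and compound 3 can be read. The compounds shown leave open where each half-maximal inhibitory concentration lies and whether the three differ at all.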